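This account rests on a few compounds, and the source may have more. Where it says the series, first, only, none or still open, it means among the compounds named here.

In a functional assay on MDA-MB-231 cells (Homo sapiens) for inhibition, read by CCK-8 assay, with a stated time of 48 h (a higher number here means a weaker inhibitor of growth, a lower number a stronger inhibitor of growth), compound 1 (`COc1cccc(CNc2nc(Nc3ccc(N4CCN(C)CC4)cn3)ncc2Cl)c1`) gives 20300 nM while compound 2 (`CC(C)c1ccc(Nc2nc(Nc3ccc(N4CCN(C)CC4)cn3)ncc2Cl)cc1`) gives 7020 nM as the lower of the two numbers. For the measured compounds named here, the only measured step (a 2.9-fold lower number from compound 1 to compound 2 (0.46 log units; beyond the scatter)) is modest and places 4-isopropylphenyl where 3-methoxybenzyl stood, so it bears only loosely on the next change. Compound 3 (`COc1ccc(Nc2nc(Nc3ccc(N4CCN(C)CC4)cn3)ncc2Cl)cc1`) has methoxy in place of isopropyl on an aromatic carbon. No step beyond the scatter is expected, if anything a slightly higher number (a 1.4-fold higher number from compound 2 to compound 3 (0.15 log units; within the scatter)). The estimated value for compound 3 is 10000 nM (range 4000 nM to 25000 nM).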

Compound 3, concentration for 50% growth inhibition: 8020 nM
The estimate for compound 3 lay 1.2-fold (0.10 log units) above the measured number; low and high end bracket the measured number.
By their numbers in this assay, from the lowest: compounds 2 and 3 (each within the scatter of the next); then compound 1.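

In this assay, methoxy and isopropyl on the aromatic carbon para to a large group cannot be told apart, with a 1.1-fold higher number from compound 2 to compound 3 (0.06 log units; within the scatter), so this position has now seen two different groups with no step beyond the scatter. Replacing 3-methoxybenzyl with 4-methoxyphenyl gives a 2.5-fold lower number from compound 1 to compound 3 (0.40 log units; beyond the scatter), so both compounds carrying a 4-substituted phenyl on that nitrogen lie below compound 1. No measurement here offers an explanation for either step. On these data alone, whether an amine or a carboxylic acid on this carbon would stay in the same range remains open.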